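A few compounds are considered here, and "the series" means these few. Any claim that something is new, unique, unknown or untested is made for them only; others in the source may bear on it.

Measured compounds:
Compound 1 `CCN1C(=O)S/C(=C\c2ccc(N)cc2)C1=O` — 108000 nM
Compound 2 `Nc1ccc(/C=C2\SC(=O)N(Cc3cccc(Cl)c3)C2=O)cc1` — 24000 nM
Compound 3 `Nc1ccc(/C=C2\SC(=O)N(Cc3ccc(Cl)cc3)C2=O)cc1` — 77000 nM

In a functional assay on HeLa cells (Homo sapiens) for cytotoxicity, read by cell counting, with a stated time of 4 days (a higher number here means a weaker inhibitor, a lower number a stronger inhibitor), compound 3 stands second highest of the three numbers, with compound 1 nearest and compound 2 furthest, a 3.2-fold higher number from compound 2 to compound 3 (0.51 log units; beyond the scatter). Compound 4 `CN1C(=O)S/C(=C\c2ccc(N)cc2)C1=O` differs from compound 3 by hydrogen in place of 4-chlorophenyl on a saturated chain carbon bound to an amide-type nitrogen in a ring. The step that bears on this is the one a 1.4-fold lower number from compound 1 to compound 3 (0.15 log units; within the scatter), which runs the opposite way and was within the scatter; the step of a 4.5-fold lower number from compound 1 to compound 2 (0.65 log units; beyond the scatter) concerns the other chlorophenyl and bears only loosely. Since removing the 4-chlorophenyl undoes a change that made no difference beyond the scatter, no step beyond the scatter is expected in this assay for compound 4, and its value is estimated at 110000 nM (range 50000 nM to 250000 nM), a 1.4-fold higher number from compound 3 to compound 4 (0.15 log units; within the scatter).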

Compound 4, half-maximal inhibitory concentration: 97000 nM
Compound 4: the middle estimate sits 1.1-fold (0.05 log units) above what was measured; the measured number falls inside the stated range.
By their numbers in this assay, from the lowest: compound 2; then compounds 3, 4 and 1 (each within the scatter of the next).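

In this assay, the chain carbon bound to the ring nitrogen tolerates losing its substituent: hydrogen in place of 4-chlorophenyl stays within the scatter (a 1.3-fold higher number from compound 3 to compound 4 (0.10 log units; within the scatter)), as does hydrogen in place of methyl (a 1.1-fold lower number from compound 1 to compound 4 (0.05 log units; within the scatter)). Only the 3-chlorophenyl stands apart, since hydrogen in its place gives a step beyond the scatter (a 4.0-fold higher number from compound 2 to compound 4 (0.61 log units; beyond the scatter)). Nothing available explains this difference between the two chlorophenyl groups. As far as these compounds go, it remains open whether the gain needs the chlorine, as an unsubstituted phenyl or a 3-methoxyphenyl at this place would show.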